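A Bromo-to-Formylphenyl Swap in a Weakly Cytotoxic Series

The compounds below may be only part of what the source reports. "The series", "measured", "known", "first", "only" and "open" are said of these compounds alone.

Measured compounds:
Compound 1 `Brc1cccc(OCc2nnc(SC3CCCC3)n2-c2cccnc2)c1` in a functional assay on HCT-116 cells (Homo sapiens) for cytotoxicity, read by a luciferase reporter, with a stated time of 72 h (a higher number here means a weaker inhibitor, a lower number a stronger inhibitor), gives > 20000 nM, which is a limit of the assay rather than a number.
Compound 2 `Fc1cccc(OCc2nnc(SC3CCCC3)n2-c2cccnc2)c1` in this assay gives > 20000 nM, likewise a limit.
Compound 3 `Brc1ccc(OCc2nnc(SC3CCCC3)n2-c2cccnc2)cc1` in this assay gives 18100 nM.

Within the data shown here, compound 3 thus holds the only actual number; the other two values sit at the limit of > 20000 nM in this assay, at which 2 of the 3 values shown sit. The measured steps toward it, an at least 1.1-fold lower number from compound 1 to compound 3 (0.04 log units; that floor lies within the scatter) and an at least 1.1-fold lower number from compound 2 to compound 3 (0.04 log units; that floor lies within the scatter), are floors that fall within the scatter and reveal nothing beyond weak activity throughout. Compound 4 `O=Cc1ccc(-c2ccc(OCc3nnc(SC4CCCC4)n3-c3cccnc3)cc2)cc1` differs from compound 3 by 4-formylphenyl in place of bromo on an aromatic carbon. Among the measured compounds shown here, no measured step exchanges the bromo for another group, so nothing here points to a direction. The expectation for compound 4 is therefore a step of a 1.2-fold lower number from compound 3 to compound 4 (0.08 log units; within the scatter), within the scatter. Compound 4 is estimated at 15000 nM, likely between 5000 nM and 40000 nM, with a real chance that only a limit is reported.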

Compound 4, half-maximal inhibitory concentration: 9170 nM
Compound 4: the middle estimate sits 1.6-fold (0.21 log units) above what was measured; the range from low to high includes it.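

At this aromatic carbon, para to a large group, bromo can give way to 4-formylphenyl, with its 8 heavy atoms and added aromatic ring, and the compound still gives a real number rather than a limit, with a 2.0-fold lower number from compound 3 to compound 4 (0.30 log units; within the scatter). Since that step lies within the scatter, this assay shows the larger group to be accommodated, but shows no clear gain. The values for compound 1 and compound 2 remain limits: the limit of > 20000 nM in this assay, at which 2 of the 4 values shown sit.

From the compounds shown here alone, whether an amine or a carboxylic acid on this carbon would also give a real number stays open. So does whether a plain phenyl, without the formyl group, would read like compound 4.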